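This account rests on a few compounds, and the source may have more. Where it says the series, first, only, none or still open, it means among the compounds named here.

Measured so far in a physicochemical assay for solubility, using the shake flask method, measured as kinetic solubility, at pH 7.4; a lower number here means a less soluble compound, a higher number a more soluble compound:
- Compound 1 `COC(=O)c1cccc(-c2cnc(Nc3ccc(F)cc3)o2)c1` is reported only as a limit of this assay, < 1000 nM.
- Compound 2 `CN(c1ccc(F)cc1)c1ncc(-c2cccc(C(=O)O)c2)o1` gives 277000 nM.
- Compound 3 `CNC(=O)c1cccc(-c2cnc(Nc3ccc(F)cc3)o2)c1` gives 3100 nM.

Compound 3 has the lowest of the two numerical values; compound 2 is far above it, and the value of compound 1 is a limit, not a number. For the measured compounds named here, the only single step measured, an at least 3.1-fold higher number from compound 1 to compound 3 (0.49 log units; beyond the scatter), replaces one carbonyl substituent by another, and its size is bounded by the limit of compound 1 (the limit of < 1000 nM in this assay, at which 1 of the 3 values shown sits).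

Compound 4 `CNC(=O)c1cccc(-c2cnc(N(C)c3ccc(F)cc3)o2)c1` differs from compound 3 by methyl in place of hydrogen on a nitrogen on an aromatic ring. Going by the values given here, no measured step covers this change on its own. Compound 2 carries the same methyl on that nitrogen but also a carboxylic acid in place of the methylamide, so its high value cannot be split between the two changes. Compound 4 is therefore expected to move only modestly from compound 3, estimated as a 2.6-fold higher number from compound 3 to compound 4 (0.41 log units; beyond the scatter), toward a higher number. The expected value for compound 4 is 8000 nM, in a range from 2500 nM to 30000 nM.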

Compound 4, solubility: 60400 nM
Beside the measured number, compound 4's estimate is 7.6-fold (0.88 log units) below it, outside the stated range (above it).
By their numbers in this assay, from the lowest: compound 3; then compound 4; then compound 2. At a limit, below all of these: compound 1.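

In this assay, for the compounds shown here, methyl in place of hydrogen on a nitrogen on an aromatic ring proves a large change on its own, with a 19-fold higher number from compound 3 to compound 4 (1.29 log units; beyond the scatter), a step that no earlier pair could isolate. With that methyl held constant, swapping the carboxylic acid for the methylamide gives a 4.6-fold lower number from compound 2 to compound 4 (0.66 log units; beyond the scatter), so the high number of compound 2 no longer rests on the carboxylic acid alone. Nothing measured here accounts for the size of the step on that nitrogen.

Still open, going by these compounds, is whether ethyl or a longer chain on that nitrogen gives a step of similar size. Also open, on these data alone, is whether the methyl behaves alike with a dimethylamide on the carbonyl carbon, or with chlorine in place of the fluorine on the aromatic ring.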